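Ortho substituent swap on the arylpiperazine end

This account rests on a few compounds, and the source may have more. Where it says the series, first, only, none or still open, it means among the compounds named here.

Measured compounds:
Compound 1 `Cc1ccc(-c2nnc(N3CCN(C(=O)CN4CCN(c5ccccc5)CC4)CC3)nc2-c2ccc(C)cc2)cc1`: 914000 nM
Compound 2 `COc1ccccc1N1CCN(CC(=O)N2CCN(c3nnc(-c4ccc(C)cc4)c(-c4ccc(C)cc4)n3)CC2)CC1`: 59400 nM

Among the measured compounds shown here, in a functional assay on MCF7 cells (Homo sapiens) for cytotoxicity, read by MTT assay, with a stated time of 24 h (a lower number here means a stronger inhibitor, a higher number a weaker inhibitor), compound 2 gives 59400 nM, the lowest of the two numbers so far; its nearest neighbour is compound 1, which gives 914000 nM. For the measured compounds named here, the one measured step, a 15-fold lower number from compound 1 to compound 2 (1.19 log units; beyond the scatter), comes from a methoxy in place of hydrogen on an aromatic carbon.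

Compound 3 `Cc1ccc(-c2nnc(N3CCN(C(=O)CN4CCN(c5ccccc5Cl)CC4)CC3)nc2-c2ccc(C)cc2)cc1` is not yet measured. It differs from compound 2 in one place: chloro in place of methoxy on an aromatic carbon. Going by the values given here, only the step from compound 1 to compound 2 bears on this change, and it concerns a different group entering at the same aromatic carbon. A chloro keeps a substituent at that position, so some of the gain seen in a 15-fold lower number from compound 1 to compound 2 (1.19 log units; beyond the scatter) may be retained, but there is no direct measurement of a chloro there.

The estimate for compound 3 is therefore 150000 nM (range 40000 nM to 600000 nM), which would mean an expected step of a 2.5-fold higher number from compound 2 to compound 3 (0.40 log units; beyond the scatter) in this assay.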

Compound 3, half-maximal inhibitory concentration: 859000 nM
Compound 3: middle estimate off by 5.7-fold (0.76 log units), on the low side; measured number outside the range, above it.
By their numbers in this assay, from the lowest: compound 2; then compounds 3 and 1 (each within the scatter of the next).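

In this assay the swap from 2-methoxyphenyl to 2-chlorophenyl brings a 14-fold higher number from compound 2 to compound 3 (1.16 log units; beyond the scatter) and so shows that the gain seen earlier does not follow from any substituent at this aromatic carbon. Chloro in place of hydrogen gives a 1.1-fold lower number from compound 1 to compound 3 (0.03 log units; within the scatter) and so leaves the number where it stood without a substituent. Among these three compounds, only the methoxy sets its compound apart, and no measured evidence here accounts for the difference between methoxy and chloro.

The compounds shown leave open whether this gain is particular to methoxy or would also appear with an ethoxy, a hydroxyl or an amine at the same carbon. They also leave open whether a methoxy at another carbon of that ring would give a similar step.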